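The source may report more compounds than this note shows. Statements on the series, on what has been measured and on what is new or still open speak of the compounds shown alone.

- compound 1 `Cc1ccc(-c2nn(-c3ccccc3)cc2C(Nc2nc3cc(C)c(C)cc3s2)c2c(O)ccc3ccccc23)cc1` gives 22400 nM
- compound 2 `Cc1cc2nc(NC(c3cn(-c4ccccc4)nc3-c3ccc([N+](=O)[O-])cc3)c3c(O)ccc4ccccc34)sc2cc1C` gives 41100 nM
- compound 3 `COc1ccc(-c2nn(-c3ccccc3)cc2C(Nc2nc3ccccc3s2)c2c(O)ccc3ccccc23)cc1` gives 17500 nM

All three values come from a functional assay on MCF7 cells (Homo sapiens) for antiproliferative activity, read by MTT assay, with a stated time of 48 h; on this read-out higher numbers stand for weaker inhibition and lower numbers for stronger inhibition. Compound 2 lies within the scatter of compound 1, while its number is higher than that of compound 3, a gap beyond the scatter.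

Compound 4 `COc1ccc2nc(NC(c3cn(-c4ccccc4)nc3-c3ccc([N+](=O)[O-])cc3)c3c(O)ccc4ccccc34)sc2c1` keeps the rest of compound 2 and changes only the group on the amine nitrogen: 6-methoxy-1,3-benzothiazol-2-yl in place of 5,6-dimethyl-1,3-benzothiazol-2-yl on an amine nitrogen.

Within the data shown here, the only measured step is a 1.8-fold higher number from compound 1 to compound 2 (0.26 log units; within the scatter), and it is a nitro in place of a methyl on an aromatic carbon, elsewhere in the molecule. It does not touch this group, so it bears only indirectly. Among the measured compounds shown here, compound 3 differs from compound 2 in more than one place and gives no clean step. No measurement isolates the present change, so no step beyond the scatter is expected in this assay, with a slight drift towards the middle of the three values.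

The expected change is a 1.4-fold lower number from compound 2 to compound 4 (0.14 log units; within the scatter). Compound 4 is estimated at 30000 nM, with an expected range from 12000 nM to 70000 nM.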

Compound 4, half-maximal inhibitory concentration: 13300 nM
The estimate for compound 4 lay 2.3-fold (0.35 log units) above the measured number; measured number inside the range.
By their numbers in this assay, from the lowest: compounds 4, 3, 1 and 2 (each within the scatter of the next, the first and the last beyond it).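

In this assay, among these compounds, the exchange of 5,6-dimethyl-1,3-benzothiazol-2-yl for 6-methoxy-1,3-benzothiazol-2-yl on the amine nitrogen gives a 3.1-fold lower number from compound 2 to compound 4 (0.49 log units; beyond the scatter) and is the first single-place step beyond the scatter, whereas the earlier nitro-for-methyl exchange on an aromatic carbon, a 1.8-fold higher number from compound 1 to compound 2 (0.26 log units; within the scatter), stayed within it. The substitution on this group therefore changes the read-out with the nitro group and the rest of the molecule held constant. No measurement available here accounts for the step.

The exchange removes two methyl groups and adds one methoxy group at once, so the contribution of each remains unresolved. Also open, from the compounds shown here alone, are a 1,3-benzothiazol-2-yl group carrying a hydroxyl or a fluorine in place of the methoxy, and whether the step persists with methyl in place of nitro.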